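The source may report more compounds than this note shows. Statements on the series, on what has been measured and on what is new or still open speak of the compounds shown alone.

Measured in a physicochemical assay for solubility; on this read-out higher numbers stand for higher solubility and lower numbers for lower solubility:
- compound 1 `O=C(c1nc2c(C(F)(F)F)cc(-c3ccoc3)cn2c1Cl)N1CCC(c2cccs2)C1`: < 15000 nM (a limit)
- compound 2 `CC1(C)CN(C2CCN(C(=O)c3nc4c(C(F)(F)F)cc(-c5ccoc5)cn4c3Cl)CC2)C(=O)O1`: > 500000 nM (a limit)
- compound 3 `CN1CCN(C(=O)c2nc3c(C(F)(F)F)cc(-c4ccoc4)cn3c2Cl)CC1=O`: > 500000 nM (a limit)

Compound 3 stands at the limit of > 500000 nM in this assay, at which 2 of the 3 values shown sit, so its true value is not known. Compound 1 stands at the limit of < 15000 nM in this assay, at which 1 of the 3 values shown sits.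

Compound 4 `O=C(c1nc2c(C(F)(F)F)cc(-c3ccoc3)cn2c1Cl)N1CCN(C2CCCCC2)C(=O)C1` differs from compound 3 as follows: cyclohexyl in place of methyl on an amide-type nitrogen in a ring.

Going by the values given here, only one measured step bears on this change. It is large: an at least 33-fold higher number from compound 1 to compound 3 (1.52 log units; beyond the scatter). That step replaced the whole group on the carbonyl carbon, so it is only a loose guide here. Its reverse direction suggests that the carbon-only ring entering in compound 4 may lower the number, and a drop beyond the scatter is expected. Compound 2 goes against this reading, since it carries a large group yet sits at the same limit as compound 3.

The expected change is an at least 10-fold lower number from compound 3 to compound 4 (1.00 log units; beyond the scatter). For compound 4 the estimated value is 50000 nM, with an expected range of 10000 nM to 250000 nM.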

Compound 4, solubility: > 500000 nM
Compound 4: a limit, no number (the forecaster's own chance of this, stated with the estimate: 35%); middle value at least 10-fold (1.00 log units) away from the limit.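

In this assay, compound 3 and compound 4 both give limits rather than numbers, so the step between them cannot be read: the limit of > 500000 nM in this assay, at which 3 of the 4 values shown sit.

The compounds shown leave open whether cyclohexyl in place of methyl on an amide-type nitrogen in a ring changes the read-out at all, and by how much.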